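The source may hold more compounds than are shown below. What is called first, only, known or untested is meant among the compounds shown, and "the series" means these compounds.

Measured so far in a functional assay on DLD-1 cells (Homo sapiens) for antiproliferative activity, read by CellTiter-Glo, with a stated time of 72 h; a higher number here means a weaker inhibitor, a lower number a stronger inhibitor:

Compound 1, `CC1CCN(C2CCN(S(=O)(=O)c3cccnc3Cl)CC2)CC1`: > 5000 nM, a limit of the assay and not a number.
Compound 2, `Cc1cc(C)c(S(=O)(=O)N2CCC(N3CCC(CCC#N)CC3)CC2)c(C)c1`: > 5000 nM, likewise a limit of the assay.
Compound 3, `CC1CCN(C2CCN(S(=O)(=O)c3ccc(C(C)C)cc3)CC2)CC1`: 685 nM.

Compound 1 stands at the limit of this assay, with no numbered value; the limit of > 5000 nM in this assay, at which 2 of the 3 values shown sit, records that the same limit is shared by one further value in the set. Within the data shown here, compound 3 is the only compound here with a number in this assay, and its value lies clearly inside the measurable range.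

Compound 4, `CC1CCN(C2CCN(S(=O)(=O)c3ccc(Cl)c(Cl)c3)CC2)CC1`, is not yet measured. It differs from compound 1 in one place: 3,4-dichlorophenyl in place of 2-chloropyridin-3-yl on a sulfonyl sulfur. Among the measured compounds shown here, no step between measured compounds is available to size this change, so the expectation rests only on the contrast between the limit of compound 1 and the numbered value of compound 3, which shows that the group on the sulfonyl sulfur can carry a compound from the limit into the measurable range. A step toward stronger inhibition, of moderate size, is expected for compound 4, with a real chance that only a limit is again reported. The expected step is an at least 3.3-fold lower number from compound 1 to compound 4 (0.52 log units; beyond the scatter). For compound 4 the estimate in this assay is 1500 nM, within a range from 400 nM to 5000 nM.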

Compound 4, half-maximal inhibitory concentration: 2.9 nM
The estimate for compound 4 lay 520-fold (2.71 log units) above the measured number, outside the stated range (below it).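

In this assay, among these compounds, the group on the sulfonyl sulfur proves able to carry the series much further than the earlier compounds indicated: with everything else in compound 1 kept, 3,4-dichlorophenyl in place of 2-chloropyridin-3-yl gives an at least 1700-fold lower number from compound 1 to compound 4 (3.23 log units; beyond the scatter). Compound 3 and compound 4 also differ only in the group at this place; compound 3 gives 685 nM and compound 4 gives 2.9 nM, so the printed value of compound 3 did not mark the lowest number reachable through this position. The step from compound 1 can be read only as a minimum, because compound 1 carries a limit of the assay and not a number: the limit of > 5000 nM in this assay, at which 2 of the 4 values shown sit.

The change removes the ring nitrogen and adds a second chlorine in a single step, and the compounds shown do not separate these two parts of it. Also open, on these data alone, is whether a phenyl ring with a single chlorine, or one with trifluoromethyl or a carboxylic acid in place of the chlorines, would keep a number in this range.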